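Same Side-Chain Change on Two Cores, All at the Limit

The source may report more compounds than this note shows. Statements on the series, on what has been measured and on what is new or still open speak of the compounds shown alone.

Measured so far:
Compound 1 `C=CCONC(=O)Cn1cc(C(=O)NCC(=O)N[C@H](C(=O)O)C(C)C)c2ccccc21` — in a functional assay on RAW264.7 cells (Mus musculus) for inhibition, read by microscopy and resazurin assay, with a stated time of 72 h (a lower number here means a stronger inhibitor, a higher number a weaker inhibitor), compound 1 gives > 128000 nM, a limit of the assay rather than a number.
Compound 2 `C=CCONC(=O)Cn1cc(C(=O)NCC(=O)N[C@@H](CC(C)C)C(=O)O)c2ccccc21` — compound 2 gives > 128000 nM, again only a limit.
Compound 3 `CC(C)[C@H](NC(=O)CNC(=O)c1ccn(CC(=O)NOCc2ccccc2)c1)C(=O)O` — compound 3 gives > 128000 nM, also a limit.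

Compound 1 and compound 2 share one core and differ in a single place: isobutyl in place of isopropyl on a saturated chain carbon bound to an amide-type nitrogen and a carbonyl carbon. The size of this step cannot be read, since a step that the two limits leave unreadable from compound 1 to compound 2. Both values sit at the limit of > 128000 nM in this assay, at which 3 of the 3 values shown sit, so the change from compound 1 to compound 2 has left no readable trace on inhibition.

Compound 3 is built from the same atoms as compound 1, joined differently; the difference between the two cores is not broken down here. Compound 4 `CC(C)C[C@H](NC(=O)CNC(=O)c1ccn(CC(=O)NOCc2ccccc2)c1)C(=O)O` is not yet measured and stands to compound 3 as compound 2 stands to compound 1: isobutyl in place of isopropyl on a saturated chain carbon bound to an amide-type nitrogen and a carbonyl carbon. The place of the change is the same on both cores, so this is the same change made a second time.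

The expectation for compound 4 rests on two things: compound 3 itself sits at the limit, and the same change gave no readable step from compound 1 to compound 2 a step that the two limits leave unreadable from compound 1 to compound 2. Compound 4 is therefore expected to show a step that the limit leaves unreadable from compound 3 to compound 4, that is, to remain unreadable. The estimate for compound 4 in this assay is 250000 nM, with a range from 64000 nM to 1500000 nM, and most likely the assay will again report only a limit.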

Compound 4, half-maximal inhibitory concentration: > 128000 nM
Compound 4 was reported as a limit (the forecaster's own chance of this, stated with the estimate: 90%); the middle value does not contradict the limit.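

In this assay compound 4 gives > 128000 nM, which is a limit and not a number. No step can be read from compound 3 to compound 4, or on the other core from compound 1 to compound 2, because every value sits at the same limit: the limit of > 128000 nM in this assay, at which 4 of the 4 values shown sit. The compounds shown leave open how strongly any of the four inhibits, and whether isobutyl in place of isopropyl changes inhibition on either core.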